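The compounds below may be only part of what the source reports. "The series", "measured", "known", "first", "only" and "open" are said of these compounds alone.

Three compounds share a core built around a five-membered aromatic ring that carries a long chain ending in a phenyl group. Compound 1 `O=C(CCCCCCc1ccccc1)c1ncc(-c2cccc(C(=O)C(F)(F)F)c2)o1` bears a phenyl ring substituted with a trifluoroacetyl group, compound 2 `COc1ccc(-c2cnc(C(=O)CCCCCCc3ccccc3)o2)cc1` bears a 4-methoxyphenyl group, and compound 3 `O=C(CCCCCCc1ccccc1)c1ncc(-c2cnc(C(=O)CCCCCCc3ccccc3)o2)o1` joins two copies of that core. In an assay (Rattus norvegicus) for inhibition of Fatty-acid amide hydrolase 1 (Homo sapiens) (a lower number here means a stronger inhibitor, a higher number a weaker inhibitor), compound 1 gives 16 nM, compound 2 gives 100 nM, and compound 3 gives 3500 nM. Compound 2 thus holds the second highest number of the three, separated from both others by more than the scatter. Compound 4 `O=C(CCCCCCc1ccccc1)c1ncc(C(=O)N2CCOCC2)o1` is not yet measured and differs from compound 2 in one place: (morpholin-4-yl)carbonyl in place of 4-methoxyphenyl on an aromatic carbon. Going by the values given here, no single-change step between measured compounds exists to guide this, so the change is judged against the spread seen so far; a weakening is expected, a step of a 6.0-fold higher number from compound 2 to compound 4 (0.78 log units; beyond the scatter). Compound 4 is estimated at 600 nM, most likely between 150 nM and 3000 nM.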

Compound 4, inhibition constant: 24 nM
Compound 4: the middle estimate sits 25-fold (1.40 log units) above what was measured, outside the stated range (below it).
By their numbers in this assay, from the lowest: compounds 1 and 4 (each within the scatter of the next); then compound 2; then compound 3.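

In this assay, (morpholin-4-yl)carbonyl in place of 4-methoxyphenyl gives a 4.2-fold lower number from compound 2 to compound 4 (0.62 log units; beyond the scatter) and so shows that this position, next to the ring oxygen, does not need an aromatic ring for a stronger inhibitor. The entering group has the same count of heavy atoms as the one it replaces, so this single step cannot separate the roles of its carbonyl and its morpholine ring. No measurement here explains the gain.

From the compounds shown here alone, it remains open whether the morpholine oxygen matters, which a piperidine amide would address. A carboxylic acid or a simple amine at this position is also an open case.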